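The source may hold more compounds than are shown below. What is called first, only, known or untested is meant among the compounds shown, and "the series" means these compounds.

Of the compounds shown here, three have so far been measured in a functional assay on MCF7 cells (Homo sapiens) for cytotoxicity, read by MTT assay, with a stated time of 72 h; a higher number here means a weaker inhibitor of growth, a lower number a stronger inhibitor of growth. Compound 1 `N#C[Se]c1ccc(NC(=O)Oc2ccc(F)cc2)cc1` gives 8300 nM in this assay, compound 2 `CCCOC(=O)Nc1ccc([Se]C#N)cc1` gives 8000 nM, and compound 3 `O=C(Nc1ccc([Se][Se]c2ccc(NC(=O)OCc3ccc([N+](=O)[O-])cc3)cc2)cc1)OCc1ccc([N+](=O)[O-])cc1` gives 20600 nM. Compound 2 gives the lowest of the three numbers, yet its value and that of compound 1 lie within the scatter of each other, while compound 3 stands beyond it. Compound 4 `CCOC(=O)Nc1ccc([Se]C#N)cc1` has not yet been measured. It differs from compound 2 by hydrogen in place of methyl on a saturated chain carbon, two bonds along the chain from an oxygen next to a carbonyl group, so the propoxy chain becomes an ethoxy one. Among the compounds with values here, no step of this kind between measured compounds is known here, so little movement is expected, in either direction or none beyond the scatter. Compound 4 is therefore estimated at 8500 nM, within 4000 nM to 18000 nM, which is expected to mean a step of a 1.1-fold higher number from compound 2 to compound 4 (0.03 log units; within the scatter) that stays within the scatter.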

Compound 4, concentration for 50% growth inhibition: 8900 nM
Estimate against measurement, compound 4: 1.0-fold (0.02 log units) below, within the range that was stated.
By their numbers in this assay, from the lowest: compounds 2, 1 and 4 (each within the scatter of the next); then compound 3.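

In this assay, the first step read at this position is a 1.1-fold higher number from compound 2 to compound 4 (0.05 log units; within the scatter), so replacing methyl with hydrogen on this saturated chain carbon, which turns propoxy into ethoxy, gives no difference that can be told from the scatter. This rests on a single pair of compounds, and no measurement shown here bears on why the two agree. The compounds shown leave open whether a longer chain, a branched chain or an amine at this place would also stay within the scatter of compound 2.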